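Bromo to Chloro on a Benzenesulfonamide Hydrazone Series

The source may hold more compounds than are shown below. What is called first, only, known or untested is meant among the compounds shown, and "the series" means these compounds.

Three compounds have been measured in a functional assay on MCF7 cells (Homo sapiens) for antiproliferative activity, read by MTT assay; on this read-out higher numbers stand for weaker inhibition and lower numbers for stronger inhibition:
compound 1, `C/C(=N/NC(=O)c1ccc(S(N)(=O)=O)cc1)c1ccc(Br)cc1`, 2290 nM
compound 2, `C/C(=N/NC(=O)c1ccc(S(N)(=O)=O)cc1)c1ccc(Cl)cc1`, 3750 nM
compound 3, `NS(=O)(=O)c1ccc(C(=O)N/N=C\c2ccc(Br)cc2)cc1`, 1370 nM

Compound 3 gives the lowest of the three numbers; its value and that of compound 1 lie within the scatter of each other, while compound 2 stands beyond it. The difference between the cores of compound 1 and compound 3 is not broken down here. From compound 1 to compound 2 the change is chloro in place of bromo on an aromatic carbon, and in this assay it gave a 1.6-fold higher number from compound 1 to compound 2 (0.21 log units; within the scatter).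

Compound 4, `NS(=O)(=O)c1ccc(C(=O)N/N=C\c2ccc(Cl)cc2)cc1`, is not yet measured. Relative to compound 3 it carries chloro in place of bromo on an aromatic carbon, the same change as between compound 1 and compound 2. On that single precedent, a 1.6-fold higher number from compound 1 to compound 2 (0.21 log units; within the scatter), compound 4 is expected to show a 1.6-fold higher number from compound 3 to compound 4 (0.21 log units; within the scatter) in this assay. The estimate for compound 4 is 2200 nM, between 1000 nM and 5000 nM.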

Compound 4, half-maximal inhibitory concentration: 36700 nM
Beside the measured number, compound 4's estimate is 17-fold (1.22 log units) below it, outside the stated range (above it).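

In this assay, chloro in place of bromo on an aromatic carbon gave a 27-fold higher number from compound 3 to compound 4 (1.43 log units; beyond the scatter), so the change did not carry over from one core to the other at the same size: the same change on two cores in this assay, a 1.6-fold higher number (0.21 log units; within the scatter) from compound 1 to compound 2 and a 27-fold higher number (1.43 log units; beyond the scatter) from compound 3 to compound 4, 16-fold (1.21 log units) apart, beyond the scatter of two such steps

The step seen on the core of compound 1 was therefore no reliable guide to the step on the core of compound 3. Going by these compounds alone, with only one pair on each core, this does not show why the two steps differ or how the change would behave on any further core.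

As far as these compounds go, it remains open whether fluoro or methoxy in the same place on the core of compound 3 would give a number closer to that of compound 3 or compound 4.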